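A few compounds are considered here, and "the series" means these few. Any claim that something is new, unique, unknown or untested is made for them only; others in the source may bear on it.

Three esters built on a shared core were examined in a functional assay on EA.hy 926 cells (Homo sapiens) for cytotoxicity, read by MTT assay, with stated times of 24 h and 12 h, tested at 12.5 uM; a lower number here means a weaker effect, a higher number a stronger effect of the compound at the concentration tested. Compound 1 `COc1cc(/C=C/C(=O)O)ccc1OC(=O)c1nc(C)c(C)nc1C` gives 38.7% in this assay. Compound 2 `COc1ccc(/C=C/C(=O)O)cc1OC(=O)c1nc(C)c(C)nc1C` holds the same atoms as compound 1, joined differently, and the difference between the two cores is not broken down here. In this assay compound 2 gives 41.3%, a value within the usual scatter of that of compound 1. Compound 3 `Cc1nc(C)c(C(=O)Oc2ccc(/C=C/C(=O)O)cc2)nc1C` arises from compound 1 by one change: hydrogen in place of methoxy on an aromatic carbon. In this assay compound 3 gives 34.2%. The step of a number 4.5 percentage points lower from compound 1 to compound 3 (within the scatter) is within the scatter, so no real effect of this change can be read from it. The values of compound 2 and compound 3 also lie within the scatter of each other, and none of the three can be called the strongest or weakest.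

Compound 4 `Cc1nc(C)c(C(=O)Oc2cccc(/C=C/C(=O)O)c2)nc1C` has not yet been measured. It differs from compound 2 by the same kind of change: hydrogen in place of methoxy on an aromatic carbon. The surroundings are not identical: in compound 1 the methoxy that leaves sits meta to the 2-carboxyethenyl group, whereas in compound 2 it sits para to it. Going by the values given here, because the only measured example, a number 4.5 percentage points lower from compound 1 to compound 3 (within the scatter), stayed within the scatter, a step of about the same small size is expected from compound 2, namely a number 4.3 percentage points lower from compound 2 to compound 4 (within the scatter). Compound 4 is therefore estimated to give 37% in this assay, with a likely range from 28% to 46%.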

Compound 4, a percentage reported as activity, at one concentration (the size of the read-out at that concentration, not a potency): 61.6%
Compound 4: the middle estimate sits 24.6 percentage points below what was measured, outside the stated range (above it).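

In this assay, hydrogen in place of methoxy, at the place para to a 2-carboxyethenyl group, gives a number 20.3 percentage points higher from compound 2 to compound 4 (beyond the scatter). The same replacement therefore does not carry a fixed step from one core to another in this series, and the step on one core cannot stand in for the step on the other: the same change on two cores in this assay, a number 4.5 percentage points lower (within the scatter) from compound 1 to compound 3 and a number 20.3 percentage points higher (beyond the scatter) from compound 2 to compound 4, 24.8 percentage points apart, beyond the scatter of two such steps This shows that, for these two pairs, the outcome of losing the methoxy group differs with the core that carries it, but it does not show what about the cores sets the two steps apart, and two pairs give no rule for any further core.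

The compounds shown leave open whether another small group at the same place, such as hydroxy, fluorine or ethoxy, would give a value closer to that of compound 2 or to that of compound 4. They also leave open whether the step on the core of compound 2 would survive with an amide or a methyl ester in place of the carboxylic acid, or would appear at other concentrations.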